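Stripping the Side Chain from a Cytotoxic Core

The source may report more compounds than this note shows. Statements on the series, on what has been measured and on what is new or still open speak of the compounds shown alone.

Compound 1, `CN(C)CCCCCn1c2c(c3ccccc31)C(=O)c1c[n+]([O-])c3ccccc3c1C2=O`: 240 nM
Compound 2, `O=C1c2c[n+]([O-])c3ccccc3c2C(=O)c2c1c1ccccc1n2Cc1cn([C@@H]2O[C@H](CO)[C@@H](O)[C@H](O)[C@H]2O)nn1`: 420 nM

Of the compounds shown here, two have so far been measured in a toxicity assay on L02 cells (Homo sapiens) for cytotoxicity, read by MTT assay, with a stated time of 72 h; on this read-out lower numbers stand for stronger inhibition and higher numbers for weaker inhibition. Compound 1 gives 240 nM and compound 2 gives 420 nM. Compound 1 carries the lowest of the two numbers, but compound 2 sits close beside it, and the gap between them lies within the usual scatter of repeated measurements, so no order of potency can be read from these two.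

Compound 3, `O=C1c2c[n+]([O-])c3ccccc3c2C(=O)c2[nH]c3ccccc3c21`, has not yet been measured. Relative to compound 1 it shows (hydrogen in place of 5-(dimethylamino)pentyl on an aromatic nitrogen). Going by the values given here, both measured compounds bear a substituent at this aromatic nitrogen, and the bare parent has no counterpart among them, so no measured step speaks directly to this change. The expectation is for a modest weakening: a 2.7-fold higher number from compound 1 to compound 3 (0.43 log units; beyond the scatter) is estimated as a step somewhat beyond the scatter, toward a higher number. On that basis compound 3 is expected to give about 650 nM in this assay, with a plausible range from 150 nM to 2800 nM.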

Compound 3, half-maximal inhibitory concentration: 400 nM
For compound 3 the middle estimate is 1.6-fold (0.21 log units) above the measured one; measured number inside the range.
By their numbers in this assay, from the lowest: compounds 1, 3 and 2 (each within the scatter of the next).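

Going by these compounds alone, compound 3 gives the first direct reading at this aromatic nitrogen, since compounds 1 and 2 both carry a substituent there. In this assay, placing hydrogen where the 5-(dimethylamino)pentyl chain stood gives a 1.7-fold higher number from compound 1 to compound 3 (0.22 log units; within the scatter), so the whole chain, with its terminal dimethylamino group, can go without a change that can be told from the scatter of repeated measurements. The shared core with a free hydrogen on this nitrogen is therefore enough to give a value in the same range as compound 1, and the measurements available offer no explanation for this result.

The compounds shown leave open how much the length of the chain matters at this position, for example whether a single methyl group, a shorter aminoalkyl chain or a longer one would also stay within the scatter of compound 3. They also leave open whether a different chain end, such as a carboxylic acid or a morpholine ring in place of the dimethylamino group, would move the number in either direction.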